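The source may report more compounds than this note shows. Statements on the series, on what has been measured and on what is new or still open speak of the compounds shown alone.

Working notes on this series in an assay on Sf9 cells for inhibition of Amine oxidase [flavin-containing] B (Homo sapiens), with stated times of 15 min and 60 min; on this read-out higher numbers stand for weaker inhibition and lower numbers for stronger inhibition. Compound 2 `NC(=O)C1CCN1Cc1ccc(OCc2cccc(F)c2)cc1` gives 46 nM, the lowest of the three numbers in hand. Compound 3 `C#CCN(Cc1ccc(OCc2cccc(F)c2)cc1Cl)[C@@H](C)C(N)=O` gives 68 nM, which sits within the scatter of compound 2, so no order between the two can be claimed. Compound 1 `CC1(C)C[C@@H](C(N)=O)N(Cc2ccc(OCc3cccc(F)c3)cc2F)C1` gives 6350 nM, a gap to compound 2 that lies beyond the scatter. Compound 4 `NC(=O)[C@@H]1CCCN1Cc1ccc(OCc2cccc(F)c2)cc1` has not yet been measured in this assay. It differs from compound 2 by 2-carbamoylpyrrolidin-1-yl in place of 2-carbamoylazetidin-1-yl on a saturated chain carbon bound to an aromatic carbon: the saturated ring carrying the carbamoyl group is enlarged, and the carbamoyl-bearing carbon becomes a defined stereocentre. Among the measured compounds shown here, no pair of measured compounds shows this ring enlargement on its own, and compound 1 differs from compound 2 in several places at once, so its number supplies no direct step. The expectation is a modest rise in the number, quite possibly no larger than the scatter. Compound 4 is therefore estimated at 110 nM, within a range from 35 nM to 400 nM, an expected step of a 2.4-fold higher number from compound 2 to compound 4 (0.38 log units; beyond the scatter).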

Compound 4, half-maximal inhibitory concentration: 204 nM
Compound 4: the middle estimate sits 1.9-fold (0.27 log units) below what was measured; the range from low to high includes it.
By their numbers in this assay, from the lowest: compounds 2 and 3 (each within the scatter of the next); then compound 4; then compound 1.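

Among the compounds shown here, this is the first single-place reading at this position: in this assay the change from 2-carbamoylazetidin-1-yl to 2-carbamoylpyrrolidin-1-yl gives a 4.4-fold higher number from compound 2 to compound 4 (0.65 log units; beyond the scatter) and so shows that the number responds to the ring carrying the carbamoyl group. The step combines the ring enlargement with a defined stereocentre in compound 4, and this single pair cannot separate the two. Nothing in hand bears on the cause of the step.

Open, on these data alone, is whether the opposite configuration at the carbamoyl-bearing carbon of compound 4 would give a different number, and whether the trend continues to 2-carbamoylpiperidin-1-yl. Also open, as far as these compounds go, is whether the carbamoyl group itself is needed, which a carboxylic acid or a nitrile at the same ring carbon would test.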